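This account rests on a few compounds, and the source may have more. Where it says the series, first, only, none or still open, it means among the compounds named here.

Measured so far in a functional assay on A549 cells (Homo sapiens) for antiproliferative activity, read by CCK-8 assay, with a stated time of 72 h; a lower number here means a stronger inhibitor, a higher number a weaker inhibitor:
compound 1, `CC1=NN(c2ccc(C)cc2)C(=O)C12C=CC(=O)C=C2c1ccc(C)cc1`, gives 37000 nM
compound 2, `CC1=NN(c2ccc(C)cc2)C(=O)C12C=CC(=O)C=C2c1ccccc1`, gives 46300 nM
compound 3, `CC1=NN(c2cccc(Cl)c2)C(=O)C12C=CC(=O)C=C2c1ccc(C)cc1`, gives 9050 nM

Among these three numbers compound 2 stands highest. Its nearest neighbour is compound 1, with a 1.3-fold higher number from compound 1 to compound 2 (0.10 log units; within the scatter), so the two cannot be told apart; compound 3 lies further off, and from compound 1 to compound 3 the change is a 4.1-fold lower number from compound 1 to compound 3 (0.61 log units; beyond the scatter).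

Compound 4, `CC1=NN(c2ccc(Cl)cc2)C(=O)C12C=CC(=O)C=C2c1ccccc1`, has not yet been measured in this assay. It differs from compound 2 in one place: chloro in place of methyl on an aromatic carbon. Among the measured compounds shown here, one measured step bears on this: from compound 1 to compound 3 the group on the amide-type nitrogen in a ring also changed from 4-methylphenyl to a chlorophenyl, there 3-chlorophenyl, and that gave a 4.1-fold lower number from compound 1 to compound 3 (0.61 log units; beyond the scatter). The step from compound 1 to compound 2 concerns the other aromatic ring and is a 1.3-fold higher number from compound 1 to compound 2 (0.10 log units; within the scatter), so it says little here. For the measured compounds named here, the one relevant step was modest and ran toward a lower number, but the chloro in compound 4 enters para to a large group rather than as 3-chlorophenyl, so a somewhat smaller step, possibly still within the scatter, is expected. Compound 4 is therefore expected to show a 2.3-fold lower number from compound 2 to compound 4 (0.36 log units; beyond the scatter), with an estimate of 20000 nM and a range from 8000 nM to 50000 nM.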

Compound 4, half-maximal inhibitory concentration: > 100000 nM
Compound 4 was reported as a limit; the forecaster's own chance of this, stated with the estimate: 10%; at least 5.0-fold (0.69 log units) between middle value and limit.
By their numbers in this assay, from the lowest: compound 3; then compounds 1 and 2 (each within the scatter of the next). At a limit, above all of these: compound 4.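

In this assay compound 4 gives > 100000 nM, which is a limit of the assay and not a number. With the group on the amide-type nitrogen going from 4-methylphenyl to 4-chlorophenyl, chloro in place of methyl gives an at least 2.1-fold higher number from compound 2 to compound 4 (0.33 log units; beyond the scatter), so a chlorine on this aromatic ring does not by itself bring a lower number, and this step runs opposite to the earlier one with 3-chlorophenyl, a 4.1-fold lower number from compound 1 to compound 3 (0.61 log units; beyond the scatter). How far the number rises at this place cannot be read: the limit of > 100000 nM in this assay, at which 1 of the 4 values shown sits.

The two chlorine steps differ both in where the chloro sits and in the other aromatic ring, which carries a methyl in compound 1 and a hydrogen in compound 2, and although that ring change alone gives a 1.3-fold higher number from compound 1 to compound 2 (0.10 log units; within the scatter), the compounds shown do not separate these two differences once a chloro is present. They also leave open how a bromo group, a methoxy group or an amine would read at the same place on this ring.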